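Ethoxycarbonyl to Acetyl: One Change, Two Cores

A few compounds are considered here, and "the series" means these few. Any claim that something is new, unique, unknown or untested is made for them only; others in the source may bear on it.

Three compounds have been measured in an ADME assay on HaCaT cells (Homo sapiens) for inhibition, read by sulforhodamine B assay, with a stated time of 48 h; a lower number here means a stronger inhibitor of growth, a higher number a weaker inhibitor of growth:
compound 1 `C=C(C)[C@@H]1CC=C(Cn2cc(COc3cccc(C4NC(=O)NC(C)=C4C(=O)OCC)c3)nn2)CC1` gives 508000 nM;
compound 2 `C=C(C)[C@@H]1CC=C(Cn2cc(COc3ccccc3C3NC(=O)NC(C)=C3C(=O)OCC)nn2)CC1` gives 294000 nM;
compound 3 `C=C(C)[C@@H]1CC=C(Cn2cc(COc3cccc(C4NC(=O)NC(C)=C4C(C)=O)c3)nn2)CC1` gives 116000 nM.

Compound 3 differs from compound 1 in a single place: methyl in place of ethoxy on a carbonyl carbon. That change produced a 4.4-fold lower number from compound 1 to compound 3 (0.64 log units; beyond the scatter), a modest but real shift in this assay.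

Compound 2 is built from the same atoms as compound 1, joined differently; the difference between the two cores is not broken down here. In this assay the two sit close together, and the gap between compound 2 and compound 1 lies within the usual scatter, so no order between them can be claimed.

Compound 4 `C=C(C)[C@@H]1CC=C(Cn2cc(COc3ccccc3C3NC(=O)NC(C)=C3C(C)=O)nn2)CC1` has not yet been measured. It stands to compound 2 exactly as compound 3 stands to compound 1: methyl in place of ethoxy on a carbonyl carbon. The place of the change is described in the same words for both pairs, so this is the same change, carried out on the core of compound 2 instead of the core of compound 1.

The expected step for compound 4 is a 4.2-fold lower number from compound 2 to compound 4 (0.62 log units; beyond the scatter), and this expectation rests on a single precedent, because the same change gave a 4.4-fold lower number from compound 1 to compound 3 (0.64 log units; beyond the scatter). Among the measured compounds shown here, with only one example the step could be larger or smaller on a different core, so the range is kept wide. In this assay compound 4 is therefore estimated at about 70000 nM, most likely between 25000 nM and 200000 nM.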

Compound 4, concentration for total growth inhibition: 29500 nM
For compound 4 the middle estimate is 2.4-fold (0.38 log units) above the measured one; the range from low to high includes it.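

Replacing ethoxy with methyl on the carbonyl carbon also lowered the number on the second core, giving a 10-fold lower number from compound 2 to compound 4 (1.00 log units; beyond the scatter) in this assay. Set beside the earlier step, this new one does not stand apart from it, as the gap between the two is no greater than repeated measurements could produce: the same change on two cores in this assay, a 4.4-fold lower number (0.64 log units; beyond the scatter) from compound 1 to compound 3 and a 10-fold lower number (1.00 log units; beyond the scatter) from compound 2 to compound 4, 2.3-fold (0.36 log units) apart, within the scatter of two such steps. The change therefore carried over from the core of compound 1 to the core of compound 2 in direction and, as far as the scatter allows, in size, but this does not show that the step is really larger on one core than on the other, and two pairs cannot explain why the number falls.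

The compounds shown leave open how the same carbonyl carbon would behave in this assay if it carried an amine, which would make an amide, or a longer chain such as propyl. They also leave open whether the step would appear on a third core, and so whether two matching pairs amount to a rule that holds more widely in this series.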